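Solubility notes on the triazolopyridine amide series

This account rests on a few compounds, and the source may have more. Where it says the series, first, only, none or still open, it means among the compounds named here.

Measured compounds:
compound 1 `Cc1cc(C(=O)Nc2cc(Oc3ccc4nc(NC(=O)C5CC5)cn4c3)ccc2C)n(C)n1`, 2.9 ug/mL
compound 2 `Cc1nc(C(=O)Nc2cc(Oc3ccc4nc(NC(=O)C5CC5)nn4c3)ccc2C)c(C)s1`, 0.16 ug/mL

In a physicochemical assay for solubility, measured as kinetic solubility, at pH 6.8 (a lower number here means a less soluble compound, a higher number a more soluble compound), compound 1 gives 2.9 ug/mL. In the same assay compound 2 gives 0.16 ug/mL, the lower of the two numbers by a margin well beyond the scatter; compound 1 is the nearest neighbour. Compounds 1 and 2 differ in two places at once, so nothing single-point can be drawn from that pair.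

The next compound in this assay is compound 3 `Cc1ccc(Oc2ccc3nc(NC(=O)C4CC4)nn3c2)cc1NC(=O)CC(C)C`. Relative to compound 2 the change is isobutyl in place of 2,5-dimethyl-1,3-thiazol-4-yl on a carbonyl carbon, the aromatic amide cap giving way to a short branched chain.

Within the data shown here, no measured step of this type exists in the set, so the size of the move is uncertain. On the available numbers an increase in solubility is expected, because compound 2 sits at the bottom of the range with 0.16 ug/mL and the change removes a ring. The expected step is a 6.3-fold higher number from compound 2 to compound 3 (0.80 log units; beyond the scatter). For compound 3 the estimate is 1 ug/mL, with a plausible range from 0.2 ug/mL to 5 ug/mL.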

Compound 3, solubility: 12 ug/mL
Compound 3: middle estimate off by 12-fold (1.08 log units), on the low side, outside the stated range (above it).
By their numbers in this assay, from the lowest: compound 2; then compound 1; then compound 3.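

In this assay, among these compounds, the carbonyl carbon whose other neighbour is the amide-type nitrogen now proves to be a place where the number can move a long way: isobutyl in place of 2,5-dimethyl-1,3-thiazol-4-yl gives a 75-fold higher number from compound 2 to compound 3 (1.88 log units; beyond the scatter), the first single-place comparison, and a large one. This one step carries the whole exchange at once, the five-membered aromatic ring with its sulfur, nitrogen and two methyl groups leaving and a ring-free chain of carbon only entering, so it cannot assign the move to any one of these parts. No measurement is available that explains the size of this step.

As far as these compounds go, it remains open whether the step belongs to the loss of the ring itself or to what the ring carries, and a plain phenyl or an unsubstituted thiazolyl on the same carbonyl carbon would divide those two readings. From the compounds shown here alone, it is equally open how the number responds along the chain, where a longer chain, or a chain ending in an amine or a carboxylic acid, would show whether isobutyl is a single case or part of a trend.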